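This account rests on a few compounds, and the source may have more. Where it says the series, first, only, none or still open, it means among the compounds named here.

Going by the values given here, in an ADME assay on MT4 cells (Homo sapiens) for cytotoxicity, read by MTT assay, with a stated time of 4 days (on this read-out higher numbers stand for lower toxicity in this test and lower numbers for higher toxicity in this test), compound 1 `CCCNc1nc(C(C)c2c(F)cccc2F)c(C)c(=O)[nH]1` gives 35000 nM, the only exact number so far. Compound 2 `CCN(CC)c1nc(Cc2c(F)cccc2F)c(C)c(=O)[nH]1` gives > 81000 nM, which is a limit and not a number. Compound 3 `Cc1c(C(C)c2c(F)cccc2F)nc(N2CCCC2)[nH]c1=O` has not yet been measured. It differs from compound 1 on the shared core by having pyrrolidin-1-yl in place of propylamino on an aromatic carbon. Among the compounds with values here, no measured pair shows this change on its own. The expected step of a 1.1-fold higher number from compound 1 to compound 3 (0.06 log units; within the scatter) is small, with no shift beyond the usual scatter in this assay. For compound 3 the estimate is 40000 nM, with an expected range from 15000 nM to 100000 nM.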

Compound 3, half-maximal cytotoxic concentration: > 78000 nM
Compound 3: no number, only a limit; the forecaster's own chance of this, stated with the estimate: 30%; middle value at least 1.9-fold (0.29 log units) from the limit.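

Placing pyrrolidin-1-yl instead of propylamino on this aromatic carbon, between two ring nitrogen atoms, gives an at least 2.2-fold higher number from compound 1 to compound 3 (0.34 log units; beyond the scatter) in this assay, meaning lower toxicity in this test. Going by these compounds alone, this is the first single change at this position that can be read, since the earlier compounds offered no such pair. The full size of the step stays unknown, because the value for compound 3 is a limit and not a number: the limit of > 78000 nM in this assay, at which 1 of the 3 values shown sits.

Whether the ring or the missing hydrogen-bond donor accounts for the step stays open. So does the outcome with a morpholin-4-yl ring or an ethylamino chain here.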